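Adding a Second Chloro to the Carbamate Phenyl

This account rests on a few compounds, and the source may have more. Where it says the series, first, only, none or still open, it means among the compounds named here.

Three compounds share one core and differ only in the phenyl group of the carbamate. In an assay on frontal cortex for displacement of a labelled ligand from corticotropin-releasing factor receptor 1 (Rattus norvegicus), with a stated time of 2 h (a higher number here means a weaker inhibitor, a lower number a stronger inhibitor), compound 1 `COc1nc(C)c(Nc2nc(Cl)cn([C@H](COC(=O)Nc3ccccc3)C3CC3)c2=O)cc1C` gives 1.5 nM, compound 2 `COc1nc(C)c(Nc2nc(Cl)cn([C@H](COC(=O)Nc3ccccc3Cl)C3CC3)c2=O)cc1C` gives 1.5 nM, and compound 3 `COc1nc(C)c(Nc2nc(Cl)cn([C@H](COC(=O)Nc3ccc(Cl)cc3)C3CC3)c2=O)cc1C` gives 1.6 nM. Compound 3 sits within the scatter of both others: a 1.1-fold higher number from compound 1 to compound 3 (0.03 log units; within the scatter) and a 1.1-fold higher number from compound 2 to compound 3 (0.03 log units; within the scatter). Compound 4 `COc1nc(C)c(Nc2nc(Cl)cn([C@H](COC(=O)Nc3ccc(Cl)cc3Cl)C3CC3)c2=O)cc1C` differs from compound 3 by chloro in place of hydrogen on an aromatic carbon. The same kind of change has already been made twice on this phenyl: no change at the digits printed from compound 1 to compound 2 (within the scatter) and a 1.1-fold higher number from compound 1 to compound 3 (0.03 log units; within the scatter). Neither moved the number beyond the scatter, so no shift beyond the scatter is expected this time either, a 1.1-fold higher number from compound 3 to compound 4 (0.03 log units; within the scatter). Compound 4 is therefore estimated at 1.7 nM, with an expected range from 0.8 nM to 3.5 nM.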

Compound 4, half-maximal inhibitory concentration: 1.7 nM
Compound 4: the middle estimate sits on the measured number at the digits printed, within the range that was stated.
By their numbers in this assay, from the lowest: compounds 1, 2, 3 and 4 (each within the scatter of the next).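

In this assay, compound 4 shows that the two chloro groups can sit on this phenyl together and the number still stays within the scatter: a 1.1-fold higher number from compound 3 to compound 4 (0.03 log units; within the scatter), a 1.1-fold higher number from compound 2 to compound 4 (0.05 log units; within the scatter) and a 1.1-fold higher number from compound 1 to compound 4 (0.05 log units; within the scatter). Going from phenyl to 2-chlorophenyl reads the same as going from 4-chlorophenyl to 2,4-dichlorophenyl: the same change on two cores in this assay, no change at the digits printed (within the scatter) from compound 1 to compound 2 and a 1.1-fold higher number (0.03 log units; within the scatter) from compound 3 to compound 4, 1.1-fold (0.03 log units) apart, within the scatter of two such steps. Likewise, going from phenyl to 4-chlorophenyl reads the same as going from 2-chlorophenyl to 2,4-dichlorophenyl: the same change on two cores in this assay, a 1.1-fold higher number (0.03 log units; within the scatter) from compound 1 to compound 3 and a 1.1-fold higher number (0.05 log units; within the scatter) from compound 2 to compound 4, 1.1-fold (0.03 log units) apart, within the scatter of two such steps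

These four compounds carry only hydrogen or chloro on this phenyl. On these data alone, how an amine or a carboxylic acid on the ring would read remains open, as does a longer chain in place of the phenyl.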